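A few compounds are considered here, and "the series" means these few. Any claim that something is new, unique, unknown or untested is made for them only; others in the source may bear on it.

Measured so far:

compound 1, `CCCCCC(=O)Nc1ccc(S(=O)(=O)Oc2ccccc2C(C)C)cc1`: 6400 nM
compound 2, `CCCCCC(=O)Nc1ccc(S(=O)(=O)Oc2ccccc2I)cc1`: 13000 nM
compound 3, `CCCNC(=O)Nc1ccc(S(=O)(=O)Oc2ccccc2C(C)C)cc1`: 6300 nM

In a functional assay on HT-29 cells (Homo sapiens) for antiproliferative activity, read by sulforhodamine B assay, with a stated time of 48 h (a lower number here means a stronger inhibitor, a higher number a weaker inhibitor), compound 2 gives the highest number of the three. Its nearest neighbour is compound 1, reached by a 2.0-fold higher number from compound 1 to compound 2 (0.31 log units; beyond the scatter); the furthest is compound 3, whose value stands further below it by a similar margin. Compound 1 and compound 3 are not separated beyond the scatter: a 1.0-fold lower number from compound 1 to compound 3 (0.01 log units; within the scatter).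

Compound 4, `O=C(NCCCCl)Nc1ccc(S(=O)(=O)Oc2ccccc2I)cc1`, is the next member. Relative to compound 2 it carries (3-chloropropyl)amino in place of pentyl on a carbonyl carbon. For the measured compounds named here, the one measured step that bears on this change is the exchange on the carbonyl carbon seen between compound 1 and compound 3, a 1.0-fold lower number from compound 1 to compound 3 (0.01 log units; within the scatter), which stayed within the scatter. Going by the values given here, the entering (3-chloropropyl)amino group differs from the propylamino group of compound 3 by its chlorine, and no measured pair tests that part of the change. On the evidence available, the expectation for this assay is no step beyond the scatter: no change at the digits printed from compound 2 to compound 4 (within the scatter). The estimate for compound 4 is 13000 nM, with a range from 6000 nM to 28000 nM.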

Compound 4, half-maximal inhibitory concentration: 9600 nM
Beside the measured number, compound 4's estimate is 1.4-fold (0.13 log units) above it; the measured number falls inside the stated range.
By their numbers in this assay, from the lowest: compounds 3, 1, 4 and 2 (each within the scatter of the next, the first and the last beyond it).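

In this assay, the second exchange on this carbonyl carbon also stays within the scatter (a 1.4-fold lower number from compound 2 to compound 4 (0.13 log units; within the scatter)), this time on the iodo-bearing member and with (3-chloropropyl)amino entering in place of pentyl. Together with the exchange on the isopropyl-bearing member (a 1.0-fold lower number from compound 1 to compound 3 (0.01 log units; within the scatter)), this shows two replacements of pentyl by a nitrogen-linked chain on two different members, and neither moves the number beyond the scatter. No measured evidence accounts for this flat response.

The contribution of the chlorine itself stays open, as the compounds shown hold no pair setting (3-chloropropyl)amino against propylamino on the same core. Also open, from the compounds shown here alone, is whether a terminal amine, a carboxylic acid or a longer alkyl chain on this carbonyl carbon would give a step beyond the scatter.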